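This account rests on a few compounds, and the source may have more. Where it says the series, first, only, none or still open, it means among the compounds named here.

For the measured compounds named here, compound 1 `CC(=O)N[C@@H]1[C@@H](OC(C)=O)[C@H](OC(C)=O)[C@@H](COC(C)=O)O[C@H]1n1nc(SCc2ccccc2)nc1-c1cc2ccccc2[nH]1` is the one compound here with a numeric reading: in a functional assay on HepG2 cells (Homo sapiens) for antiproliferative activity, read by sulforhodamine B assay, with a stated time of 48 h (on this read-out lower numbers stand for stronger inhibition and higher numbers for weaker inhibition), compound 1 gives 16.6 ug/mL. Compound 2 `CC(=O)N[C@@H]1[C@@H](OC(C)=O)[C@H](OC(C)=O)[C@@H](COC(C)=O)O[C@H]1n1nc(-c2cc3ccccc3[nH]2)nc1SCc1ccccc1` gives > 100 ug/mL in this assay, which is a limit of the assay and not a number. That boundary is the limit of > 100 ug/mL in this assay, at which 1 of the 2 values shown sits. Compound 3 `CC(=O)OC[C@H]1O[C@@H](n2nc(SCc3ccccc3)nc2-c2cc3ccccc3[nH]2)[C@H](OC(C)=O)[C@@H](OC(C)=O)[C@@H]1OC(C)=O` keeps the frame of compound 1 and alters one group: acetoxy in place of acetamido on a saturated ring carbon. Going by the values given here, no measured step of this kind is available, so the change is expected to stay within the usual scatter, in no set direction. Compound 3 is therefore expected to give about 20 ug/mL in this assay, with a range from 8 ug/mL to 50 ug/mL. The expected step is a 1.2-fold higher number from compound 1 to compound 3 (0.08 log units; within the scatter).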

Compound 3, half-maximal inhibitory concentration: 16.1 ug/mL
The estimate for compound 3 lay 1.2-fold (0.09 log units) above the measured number, and the stated range covers the measured number.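

In this assay, swapping acetamido for acetoxy on this saturated ring carbon gives a 1.0-fold lower number from compound 1 to compound 3 (0.01 log units; within the scatter), so the two groups read alike at this position. Compound 3 lacks the amide hydrogen, so that hydrogen is not needed to keep this level of activity in these cells. Nothing measured here explains why the reading holds.

This one swap exchanges two groups of the same size. From the compounds shown here alone, whether a free amine, a hydroxyl group or a longer acyl chain on the same carbon would be tolerated remains open.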